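A few compounds are considered here, and "the series" means these few. Any claim that something is new, unique, unknown or untested is made for them only; others in the source may bear on it.

In a functional assay on PC-3 cells (Homo sapiens) for antiproliferative activity, read by MTT assay, with a stated time of 24 h (a higher number here means a weaker inhibitor, a lower number a stronger inhibitor), compound 1 `CCn1c(C(=O)N[C@H](CO)CCO)ccc1C(CC)(CC)c1ccc(OCS(=O)(=O)c2ccccc2)c(C)c1` gives 12100 nM, compound 2 `CCn1c(C(=O)N[C@@H](C)C(=O)O)ccc1C(CC)(CC)c1ccc(OCS(=O)(=O)c2ccccc2)c(C)c1` gives 16800 nM and compound 3 `CCn1c(C(=O)NCC(=O)O)ccc1C(CC)(CC)c1ccc(OCS(=O)(=O)c2ccccc2)c(C)c1` gives 30100 nM. Compound 3 thus sits within the scatter of compound 2 but beyond it from compound 1. Compound 4 `CCn1c(C(=O)NCCC(=O)O)ccc1C(CC)(CC)c1ccc(OCS(=O)(=O)c2ccccc2)c(C)c1` differs from compound 3 as follows: carboxymethyl in place of carboxy on a saturated chain carbon bound to an amide-type nitrogen. In words, this is carboxymethyl in place of carboxy on a saturated chain carbon bound to an amide-type nitrogen. The closest guide is the methyl change between the two carboxy compounds, a 1.8-fold higher number from compound 2 to compound 3 (0.25 log units; within the scatter). The other steps are a 1.4-fold higher number from compound 1 to compound 2 (0.14 log units; within the scatter) and the modest 2.5-fold higher number from compound 1 to compound 3 (0.40 log units; beyond the scatter), which involve a different amide substituent. The estimated change is a 1.2-fold lower number from compound 3 to compound 4 (0.08 log units; within the scatter), so no shift beyond the scatter is expected. Compound 4 is expected at 25000 nM, within an estimated range of 12000 nM to 50000 nM.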

Compound 4, half-maximal inhibitory concentration: 14400 nM
For compound 4 the middle estimate is 1.7-fold (0.24 log units) above the measured one; low and high end bracket the measured number.
By their numbers in this assay, from the lowest: compounds 1, 4, 2 and 3 (each within the scatter of the next, the first and the last beyond it).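

In this assay, among these compounds, carboxymethyl in place of carboxy on a saturated chain carbon bound to an amide-type nitrogen gives a 2.1-fold lower number from compound 3 to compound 4 (0.32 log units; beyond the scatter), the only step among the three carboxylic acids that passes the scatter. Yet 2-carboxyethyl in place of 1-carboxyethyl gives a 1.2-fold lower number from compound 2 to compound 4 (0.07 log units; within the scatter), and in place of 3-hydroxy-1-(hydroxymethyl)propyl it gives a 1.2-fold higher number from compound 1 to compound 4 (0.08 log units; within the scatter), so compound 4 cannot be told apart from compound 2 or compound 1. Nothing available accounts for these steps. From the compounds shown here alone, whether a longer chain such as 3-carboxypropyl, or an amine in place of the carboxylic acid, would hold these numbers remains open.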